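This account rests on a few compounds, and the source may have more. Where it says the series, first, only, none or still open, it means among the compounds named here.

Of the compounds shown here, three have been measured in an ADME assay on WI-38 cells (Homo sapiens) for inhibition, read by CellTiter-Glo, with a stated time of 48 h, tested at 100 uM (a lower number here means less inhibition, a higher number more inhibition at the concentration tested (going by the name of the read-out)), so far. Compound 1, with structure `CCOC(=O)/C=C/NC(=O)[C@H](O)C(C)(C)CO`, gives 36%. Compound 2, with structure `CC(C)(C)OC(=O)/C=C/NC(=O)[C@@H](O)C(C)(C)CO`, gives 14%. Compound 3, with structure `CCOC(=O)/C=C\NC(=O)[C@@H](O)C(C)(C)CO`, gives -6%, which is the lowest of the three numbers; compound 2 stands closest to it and compound 1 furthest away, both beyond the scatter.

The unmeasured compound 4 has structure `CCOC(=O)/C=C/NC(=O)[C@@H](O)C(C)(C)CO`. Compared with compound 3 the change is the two compounds have the same atoms and bonds and differ only in configuration as drawn: 1 of 2 stereo elements differ; a double bond is drawn Z in compound 3 and E in compound 4.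

Among the compounds with values here, only one measured step bears on this change. From compound 1 to compound 3 the read-out moved by a number 42 percentage points lower from compound 1 to compound 3 (beyond the scatter), and that step is explained here only by the fact that compounds 1 and 3 differ only in the configuration as drawn. It alters two stereo elements at once, the double bond and the saturated chain carbon. The share of the double bond alone in that step cannot be separated from it. Within the data shown here, compound 4 shares the drawn carbon configuration with compound 2 and compound 3 but the double-bond geometry of compound 1 and compound 2; no step between compound 2 and compound 4 is given, and their values differ in the ester group as well.

Turning the double bond from Z back to E is therefore expected to raise the number, by an estimated a number 24 percentage points higher from compound 3 to compound 4 (beyond the scatter), a step of moderate size. For compound 4 the expected value in this assay is 18%, with a range from -2% to 38%.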

Compound 4, a percentage reported as inhibition, at one concentration (the size of the read-out at that concentration, not a potency): -6%
Beside the measured number, compound 4's estimate is 24 percentage points above it; the measured number lies below the stated range.
By their numbers in this assay, from the lowest: compounds 3 and 4 (each within the scatter of the next); then compound 2; then compound 1.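

In this assay, changing the double bond alone from Z to E, with the saturated chain carbon drawn S, gives no change at the digits printed from compound 3 to compound 4 (within the scatter), so this geometry on its own does not move the number in this setting. Changing only the stereocentre at the saturated chain carbon from R to S, with the double bond drawn E, gives a number 42 percentage points lower from compound 1 to compound 4 (beyond the scatter), so among these compounds the large difference follows the configuration at that carbon, as the pair has nothing else to account for it: the fact that compounds 1 and 4 differ only in the configuration as drawn Ethyl in place of tert-butyl on an oxygen next to a carbonyl group gives a number 20 percentage points lower from compound 2 to compound 4 (beyond the scatter), which shows that the ester group also changes the number when the carbon is drawn S and the double bond E.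

The compounds shown leave open whether the double bond counts for as little when the saturated chain carbon is drawn R, and whether the ethyl and tert-butyl groups differ in the same way there. They also leave open how the number would respond to a carboxylic acid in place of the ester, or to a longer chain on that oxygen.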